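Trimming the carbinol of compound 1 to an acetyl

The compounds below may be only part of what the source reports. "The series", "measured", "known", "first", "only" and "open" are said of these compounds alone.

Compound 1 `CC#C[C@H]1CN(S(=O)(=O)c2ccc(N)nc2)CCN1c1ccc([C@@](O)(CO)C(F)(F)F)cc1` gives 89 nM in an assay on cells (Hepatocyte) for inhibition of glucokinase regulatory protein (Mus musculus), with stated times of 20 min and 40 min; a higher number here means that more compound is needed for the effect, a lower number that less compound is needed.
Compound 3 `CC#CCC(O)(c1ccc(N2CCN(S(=O)(=O)c3ccc(N)nc3)C[C@@H]2C#CC)cc1)C(F)(F)F` gives 137 nM in this assay.
Compound 2 `CC#C[C@H]1CN(S(=O)(=O)c2ccc(N)nc2)CCN1c1ccc(S(=O)(=O)Nc2ccccc2)cc1` gives only a limit, > 12500 nM, in this assay.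

Among the two numbers shown, compound 1 holds the lowest, with compound 3 nearest: the change a 1.5-fold higher number from compound 1 to compound 3 (0.19 log units; within the scatter) stays within the scatter, so the two cannot be ordered. The third entry is a limit, not a number, and the limit of > 12500 nM in this assay, at which 1 of the 3 values shown sits, is where it sits. The change an at least 140-fold higher number from compound 1 to compound 2 (2.14 log units; beyond the scatter) is large, showing that the trifluoromethyl carbinol on the shared core can be replaced by a second carbinol bearing a trifluoromethyl with little consequence, but that a quite different group at the same position loses the effect altogether.

Compound 4 `CC#C[C@H]1CN(S(=O)(=O)c2ccc(N)nc2)CCN1c1ccc(C(C)=O)cc1` is not yet measured. Its difference from compound 1 is a group of 3 heavy atoms (2 carbon, 1 oxygen; no ring) in place of a group of 8 heavy atoms (3 carbon, 2 oxygen, 3 fluorine; no ring), on an aromatic carbon. Both measured steps bear on this: the one within the scatter exchanged one carbinol for another, whereas the acetyl keeps neither the hydroxyl groups nor the trifluoromethyl of compound 1, and the large step to compound 2 shows how far the number can rise when that group is gone. A clear rise in this assay is therefore expected, a 28-fold higher number from compound 1 to compound 4 (1.45 log units; beyond the scatter), smaller than the step to compound 2 but well beyond the scatter. Compound 4 is estimated at 2500 nM, between 500 nM and 12500 nM.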

Compound 4, half-maximal effective concentration: > 12500 nM
Compound 4: a limit, no number; the forecaster's own chance of this, stated with the estimate: 30%; middle value at least 5.0-fold (0.69 log units) away from the limit.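

Going from a carbinol to the acetyl is a large loss in this assay, with an at least 140-fold higher number from compound 1 to compound 4 (2.14 log units; beyond the scatter) and an at least 91-fold higher number from compound 3 to compound 4 (1.96 log units; beyond the scatter). Until now the only group shown to lose the effect at this position was the phenylsulfamoyl, which carries a ring of its own, whereas the acetyl is a small group with no ring, so a ring is not required for the loss, and the two compounds that keep the effect, compound 1 and compound 3, both carry a hydroxyl and a trifluoromethyl on the same carbon. Compound 4 gives only a limit of the assay, as compound 2 does, so the step between these two cannot be read and they cannot be ordered: the limit of > 12500 nM in this assay, at which 2 of the 4 values shown sit.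

Which part of the carbinol matters remains open, as no compound here has the hydroxyl without the trifluoromethyl, or the trifluoromethyl without the hydroxyl. A 1-hydroxyethyl group, with the hydroxyl and no fluorine, or a trifluoroacetyl group, with the fluorines and no hydroxyl, would pull the two apart at this position.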